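Compound 3: the chloro of compound 2 removed

The source may hold more compounds than are shown below. What is called first, only, known or untested is meant among the compounds shown, and "the series" means these compounds.

Measured in a functional assay on MDA-MB-231 cells (Homo sapiens) for antiproliferative activity, read by MTT assay, with a stated time of 48 h; on this read-out higher numbers stand for weaker inhibition and lower numbers for stronger inhibition:
Compound 1 `C/C(=C\CC/C(C)=C/CC[C@@H]1[C@@]2(C)CCC(=O)C(C)(C)[C@H]2CC[C@@]1(C)O)CC/C=C(\C)C(=O)OCc1cn(-c2ccccc2C)nn1`: > 150000 nM, a limit of the assay
Compound 2 `C/C(=C\CC/C(C)=C/CC[C@@H]1[C@@]2(C)CCC(=O)C(C)(C)[C@H]2CC[C@@]1(C)O)CC/C=C(\C)C(=O)OCc1cn(-c2cccc(Cl)c2)nn1`: 103000 nM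

Going by the values given here, compound 2 holds the only actual number so far. Compound 3 `C/C(=C\CC/C(C)=C/CC[C@@H]1[C@@]2(C)CCC(=O)C(C)(C)[C@H]2CC[C@@]1(C)O)CC/C=C(\C)C(=O)OCc1cn(-c2ccccc2)nn1` differs from it by hydrogen in place of chloro on an aromatic carbon. Among the compounds with values here, the one measured step that bears on this, an at least 1.4-fold lower number from compound 1 to compound 2 (0.16 log units; that floor lies within the scatter), exchanges 2-methylphenyl for 3-chlorophenyl. On that slim basis, no step beyond the scatter is expected in this assay. The expected change is a 1.3-fold higher number from compound 2 to compound 3 (0.10 log units; within the scatter). Compound 3 is estimated at 130000 nM, with an expected range of 70000 nM to 240000 nM.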

Compound 3, half-maximal inhibitory concentration: > 150000 nM
Compound 3 was reported as a limit (the forecaster's own chance of this, stated with the estimate: 40%); middle value at least 1.1-fold (0.06 log units) away from the limit.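

In this assay, hydrogen in place of chloro on the aromatic carbon gives an at least 1.4-fold higher number from compound 2 to compound 3 (0.16 log units; that floor lies within the scatter), so the true size of this step may exceed its floor or may stay within the scatter. Compound 3 gives > 150000 nM, a limit of the assay, and the step between compound 1 and compound 3 cannot be read. Only compound 2 holds a number, and the other two share one limit: the limit of > 150000 nM in this assay, at which 2 of the 3 values shown sit.

Going by these compounds, whether the chloro truly matters at this place stays open, and so does what an amine or a carboxylic acid there would do.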